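Replacing the 1-methylethenyl group with a hydroxylated analogue

The source may hold more compounds than are shown below. What is called first, only, known or untested is meant among the compounds shown, and "the series" means these compounds.

Compound 1 `CN1CCCN(CCn2ccc3ccc(C(N)=O)cc32)CC1`: 33%
Compound 2 `Cc1ccc2ccn(CCN3CCCN(C)CC3)c2c1`: 62%
Compound 3 `C=C(C)c1ccc2ccn(CCN3CCCN(C)CC3)c2c1`: 72%

In an assay on HEK293 cells for binding affinity to 5-hydroxytryptamine receptor 7 (Homo sapiens), read by radioligand binding, tested at 1 uM (a higher number here means more inhibition at the concentration tested (going by the name of the read-out), a lower number less inhibition), compound 3 gives the highest of the three numbers. Its nearest neighbour is compound 2, which sits within the scatter of it, while compound 1 lies well below (a number 39 percentage points higher from compound 1 to compound 3 (beyond the scatter)). Compound 4 `CN1CCCN(CCn2ccc3ccc(C(C)(C)O)cc32)CC1` differs from compound 3 in one place: 1-hydroxy-1-methylethyl in place of 1-methylethenyl on an aromatic carbon. The entering 1-hydroxy-1-methylethyl carries a hydrogen-bond donor and acceptor, which the leaving 1-methylethenyl lacks. Going by the values given here, no measured step exchanges these two groups. Among the compounds with values here, the steps that bear on it are a number 29 percentage points higher from compound 1 to compound 2 (beyond the scatter) and a number 39 percentage points higher from compound 1 to compound 3 (beyond the scatter), both removing the carbamoyl group, whereas a number 10 percentage points higher from compound 2 to compound 3 (within the scatter) stays within the scatter. Going the other way, a drop is expected, a number 27 percentage points lower from compound 3 to compound 4 (beyond the scatter). The estimate for compound 4 is 45%, within 25% to 65%.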

Compound 4, a percentage reported as inhibition, at one concentration (the size of the read-out at that concentration, not a potency): 6%
Estimate against measurement, compound 4: 39 percentage points above, outside the stated range (below it).
By their numbers in this assay, from the lowest: compound 4; then compound 1; then compounds 2 and 3 (each within the scatter of the next).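

The result in this assay shows that this position, on an aromatic carbon of the core, does not accept every group of this size equally, with a number 66 percentage points lower from compound 3 to compound 4 (beyond the scatter) against 1-methylethenyl and a number 56 percentage points lower from compound 2 to compound 4 (beyond the scatter) against methyl. Carbamoyl had given the lowest number so far, yet a number 27 percentage points lower from compound 1 to compound 4 (beyond the scatter) places the new group under it as well. Nothing measured here explains this loss.

Going by these compounds, whether the hydroxyl itself drives the drop stays open. An isopropyl group or the methyl ether of the 1-hydroxy-1-methylethyl group at this position would separate the oxygen from the branched carbon.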